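What Inverting One Stereocentre May Do to Compound 1

This account rests on a few compounds, and the source may have more. Where it says the series, first, only, none or still open, it means among the compounds named here.

In a functional assay on HT-29 cells (Homo sapiens) for cytotoxicity, read by MTT assay (on this read-out lower numbers stand for stronger inhibition and higher numbers for weaker inhibition), compound 1 (`CC(=O)O[C@@H]1OC(=O)[C@](C)(C(C)=O)[C@@H]1C`) gives 5000 nM. Compound 3 (`CC(=O)O[C@@H]1OC(=O)[C@](C)(C(=O)CBr)[C@@H]1C`), which carries a bromo group, gives 6000 nM, within the scatter of compound 1. Compound 2 (`CC(=O)O[C@@H]1OC(=O)[C@](Cc2ccccc2)(C(C)=O)[C@@H]1C`), which carries a phenyl group, gives 40000 nM. Compound 4 (`CC(=O)O[C@@H]1OC(=O)[C@@](C)(C(C)=O)[C@@H]1C`) changes only the spatial arrangement: the two compounds have the same atoms and bonds and differ only in configuration as drawn: 1 of 3 stereo elements differ; a stereocentre at a saturated ring carbon is drawn S in compound 1 and R in compound 4. Neither measured step involves such a change, so they offer only loose guidance: a 1.2-fold higher number from compound 1 to compound 3 (0.08 log units; within the scatter) lies within the scatter, and an 8.0-fold higher number from compound 1 to compound 2 (0.90 log units; beyond the scatter) is modest. A step larger than the phenyl one is not expected, and the estimate leans slightly towards a higher number, at a 1.8-fold higher number from compound 1 to compound 4 (0.26 log units; within the scatter). For compound 4 the expected value is 9000 nM, with an estimated range of 2500 nM to 30000 nM.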

Compound 4, half-maximal inhibitory concentration: 12000 nM
Estimate against measurement, compound 4: 1.3-fold (0.12 log units) below; the measured number falls inside the stated range.
By their numbers in this assay, from the lowest: compounds 1, 3 and 4 (each within the scatter of the next, the first and the last beyond it); then compound 2.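

Configuration at this saturated ring carbon counts in this assay: going from S to R gives a modest step (a 2.4-fold higher number from compound 1 to compound 4 (0.38 log units; beyond the scatter)). The earlier steps shown here each added a group, so they could not show what spatial arrangement alone does. Here the step can be traced to that arrangement, because nothing else separates the pair: the fact that compounds 1 and 4 differ only in the configuration as drawn.

From the compounds shown here alone, whether the same inversion would act alike in compound 2 or compound 3 remains open. So does how an amine or a carboxylic acid on the shared core would read.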